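The source may hold more compounds than are shown below. What is called first, only, known or untested is meant among the compounds shown, and "the series" means these compounds.

Compound 1 `C=C1CC[C@@H]2[C@](C)(CNCc3ccc(C)cc3)[C@H](O)CC[C@@]2(C)[C@@H]1/C=C/C1=CCOC1=O` gives 740 nM in a functional assay on BMMC cells (Mus musculus, strain C57BL/6) for inhibition, with stated times of 5 days and 48 h; on this read-out higher numbers stand for weaker inhibition and lower numbers for stronger inhibition.
Compound 2 `C=C1CC[C@@H]2[C@](C)(CNCc3ccc(F)cc3)[C@H](O)CC[C@@]2(C)[C@@H]1/C=C/C1=CCOC1=O` gives 350 nM in this assay.
Compound 3 `C=C1CC[C@@H]2[C@](C)(CNCc3ccc(Cl)cc3)[C@H](O)CC[C@@]2(C)[C@@H]1/C=C/C1=CCOC1=O` has not yet been measured in this assay.

Among the measured compounds shown here, of the two numbers so far, compound 2 holds the lower one, and the single measured step, a 2.1-fold lower number from compound 1 to compound 2 (0.33 log units; beyond the scatter), is the only guide available. Compound 3 keeps the whole shared core of compound 2 and differs only at the far end of the benzyl arm: chloro in place of fluoro on an aromatic carbon. The measured step shows that this aromatic carbon tolerates an exchange of a small group, but it compares methyl with fluoro, not fluoro with chloro, so it bears on the new change only loosely. The expectation in this assay is therefore a small step, of either sign, about as large as the scatter. Compound 3 is expected to give 400 nM in this assay, with a plausible range from 150 nM to 1000 nM. That estimate amounts to an expected 1.1-fold higher number from compound 2 to compound 3 (0.06 log units; within the scatter).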

Compound 3, half-maximal inhibitory concentration: 420 nM
Beside the measured number, compound 3's estimate is 1.1-fold (0.02 log units) below it; measured number inside the range.
By their numbers in this assay, from the lowest: compounds 2, 3 and 1 (each within the scatter of the next, the first and the last beyond it).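

Chloro in place of fluoro on this aromatic carbon gives a 1.2-fold higher number from compound 2 to compound 3 (0.08 log units; within the scatter) in this assay and so cannot be told apart from fluoro here. Chloro in place of methyl gives a 1.8-fold lower number from compound 1 to compound 3 (0.25 log units; within the scatter) and also stays within the scatter, so compound 3 sits close to both compound 1 and compound 2, even though those two are separated by a step beyond the scatter. This position therefore accepts a second halogen with no clear loss, and the three groups shown span only a narrow band of numbers.

As far as these compounds go, what a methoxy group, an amine or a carboxylic acid on this carbon would give remains open, as does chloro on another carbon of the ring. No available data explain why these three groups give such similar numbers.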